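Bromo in Place of Methyl: Expected Tolerance of Compound 4

This account rests on a few compounds, and the source may have more. Where it says the series, first, only, none or still open, it means among the compounds named here.

Going by the values given here, compound 3 `Cc1ccccc1NC(=O)CSc1nccn1-c1ccc(Cl)cc1` gives in an ADME assay on MT4 cells (Homo sapiens) for cytotoxicity, read by MTT assay (a lower number here means that less compound is tolerated, a higher number that more compound is tolerated), a value of 160000 nM, the only plain number among the three compounds measured so far. Compound 1 `O=C(CSc1nccn1-c1ccc(Cl)cc1)Nc1ccccc1F` reaches only a limit of the assay in this assay, namely > 345000 nM. Compound 2 `O=C(CSc1nccn1-c1ccc(Cl)cc1)Nc1ccccc1[N+](=O)[O-]` likewise gives only a limit in this assay, > 321000 nM. The step of an at least 2.1-fold lower number from compound 1 to compound 3 (0.33 log units; beyond the scatter) and the step of an at least 2.0-fold lower number from compound 2 to compound 3 (0.30 log units; that floor lies within the scatter) both bring the number down, while the step that the two limits leave unreadable from compound 1 to compound 2 cannot be read. Compound 4 `O=C(CSc1nccn1-c1ccc(Cl)cc1)Nc1ccccc1Br` differs from compound 3 by bromo in place of methyl on an aromatic carbon. Among the compounds with values here, the steps that bear on this change run the other way, from a fluoro or a nitro to a methyl, and both lowered the number; a halogen entering in place of the methyl is therefore expected to move the number back up in this assay, by a step of a 1.6-fold higher number from compound 3 to compound 4 (0.19 log units; within the scatter). Compound 4 is thus estimated to give 250000 nM, within a range from 120000 nM to 295000 nM.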

Compound 4, half-maximal cytotoxic concentration: > 300000 nM
Compound 4 was reported as a limit (the forecaster's own chance of this, stated with the estimate: 50%); middle value at least 1.2-fold (0.07 log units) from the limit.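

Compound 4 also reaches only a limit in this assay: the limit of > 300000 nM in this assay, at which 1 of the 4 values shown sits.

Bromo in place of methyl at this position, on an aromatic carbon ortho to a large group, gives an at least 1.8-fold higher number from compound 3 to compound 4 (0.27 log units; that floor lies within the scatter), so this change points the same way as the fluoro and nitro comparisons, though its floor alone does not establish a step beyond the scatter. Going by these compounds alone, compound 3, with its methyl, remains the only one of the four compounds with a plain number, and the steps among compound 1, compound 2 and compound 4 cannot be read.

Going by these compounds, how far the true numbers of those three compounds lie beyond their limits remains open. So does whether the lower number of compound 3 is specific to methyl or would also appear with an ethyl, a methoxy or an amine at this position.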